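A few compounds are considered here, and "the series" means these few. Any claim that something is new, unique, unknown or untested is made for them only; others in the source may bear on it.

Measured so far:
compound 1 `CN(C)c1ccc(Nc2nccc(-c3ccco3)n2)cc1`: 1900 nM
compound 2 `c1ccc(Nc2nccc(-c3cccs3)n2)cc1`: 31700 nM

In a functional assay for inhibition, with Homo sapiens as the target (on this read-out higher numbers stand for weaker inhibition and lower numbers for stronger inhibition), compound 1 gives 1900 nM, and compound 2 gives 31700 nM. Compound 2 thus stands at the higher of the two numbers, clearly apart from compound 1. Compound 3 `c1ccc(Nc2nccc(-c3ccco3)n2)cc1` is not yet measured and differs from compound 2 in one place: furan-2-yl in place of thiophen-2-yl on an aromatic carbon. Among the compounds with values here, no measured pair isolates this change, so the expectation rests on the structural change alone. In this assay a small step toward a lower number is expected, a 1.8-fold lower number from compound 2 to compound 3 (0.25 log units; within the scatter), probably within the scatter. For compound 3 the estimate in this assay is 18000 nM, ranging from 6000 nM to 50000 nM.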

Compound 3, half-maximal inhibitory concentration: 32000 nM
Compound 3: the middle estimate sits 1.8-fold (0.25 log units) below what was measured, within the range that was stated.
By their numbers in this assay, from the lowest: compound 1; then compounds 2 and 3 (each within the scatter of the next).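

In this assay, thiophen-2-yl and furan-2-yl on the aromatic carbon next to the ring nitrogen cannot be told apart, the step being a 1.0-fold higher number from compound 2 to compound 3 (0.00 log units; within the scatter) and lying within the scatter. Far more hangs on the other site: hydrogen in place of dimethylamino gives a 17-fold higher number from compound 1 to compound 3 (1.23 log units; beyond the scatter) as a large step beyond the scatter. Nothing measured accounts for either step.

Going by these compounds, whether the two five-membered rings also match when dimethylamino is present remains open. So does whether methylamino, methoxy or a carboxylic acid in place of dimethylamino would give a number near that of compound 1.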